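The compounds below may be only part of what the source reports. "The series", "measured", "known", "first", "only" and "open" are said of these compounds alone.

Of the compounds shown here, two of a shared core have been measured. In a physicochemical assay for acid dissociation, compound 1 `CC(=O)Nc1ccc2nc(C(C)(C)CCN(C)C)ccc2c1` gives 6.22 and compound 2 `CC(=O)Nc1ccc2nc(N(C)CCN(C)C)ccc2c1` gives 9.05, which places compound 2 highest of the two, the gap to compound 1 lying beyond the scatter. Compound 3 `CC(=O)Nc1ccc2nc(F)ccc2c1` has not yet been measured; it differs from compound 2 in one place:

fluoro in place of (2-(dimethylamino)ethyl)(methyl)amino on an aromatic carbon

Among the measured compounds shown here, no step of this kind between measured compounds is known, so the expectation for compound 3 rests on the change alone. For compound 3 a large fall is expected, a step of a number 7.05 log units lower from compound 2 to compound 3 (beyond the scatter). In this assay compound 3 is estimated at 2, with a range from 0 to 4.5.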

Compound 3, acid dissociation constant: -1.39
Compound 3: the middle estimate sits 3.39 log units above what was measured; measured number below the stated range.
By their numbers in this assay, from the lowest: compound 3; then compound 1; then compound 2.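

In this assay, fluoro in place of (2-(dimethylamino)ethyl)(methyl)amino on the aromatic carbon next to the ring nitrogen gives a step of a number 10.44 log units lower from compound 2 to compound 3 (beyond the scatter). This shows that the read-out is highly sensitive to the group at this position, and compound 3 stands lowest of the three at -1.39. Nothing at hand accounts for the size of this step. The change removes the whole chain at once, so the step cannot be divided between its parts. A simple methylamino or a chloro at this position would show how much belongs to the terminal dimethylamino and how much to the atom bound to the ring.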